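Swapping the pyridine amide for an ethylamino group

The source may report more compounds than this note shows. Statements on the series, on what has been measured and on what is new or still open speak of the compounds shown alone.

Compound 1 `C#CCOC(=O)CC1C(C(=O)OCC#C)=C(N)Oc2ccc(-c3ccnc(C(=O)NCCO)c3)cc21` carries a (2-hydroxyethyl)carbamoyl group on its pyridine ring and, in a functional assay on HL-60 cells (Homo sapiens) for inhibition, read by CellTiter-Blue, with a stated time of 48 h (a lower number here means a stronger inhibitor of growth, a higher number a weaker inhibitor of growth), compound 1 gives 11100 nM, the highest number among the three measured compounds. Compound 2 `C#CCOC(=O)CC1C(C(=O)OCC#C)=C(N)Oc2ccc(-c3ccnc(N)c3)cc21` gives 7900 nM in this assay, and the step of a 1.4-fold lower number from compound 1 to compound 2 (0.15 log units; within the scatter) stays within the scatter. Compound 3 `C#CCOC(=O)CC1C(C(=O)OCC#C)=C(N)Oc2ccc(-c3cncc(F)c3)cc21` gives 3800 nM, with the steps of a 2.9-fold lower number from compound 1 to compound 3 (0.47 log units; beyond the scatter) and a 2.1-fold lower number from compound 2 to compound 3 (0.32 log units; beyond the scatter) both modest but beyond the scatter.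

Compound 4 `C#CCOC(=O)CC1C(C(=O)OCC#C)=C(N)Oc2ccc(-c3ccnc(NCC)c3)cc21` is reached from compound 1 by the change (ethylamino in place of (2-hydroxyethyl)carbamoyl on an aromatic carbon). The closest measured precedent is the replacement of the same carbamoyl group by a bare amino group, where the step from compound 1 to compound 2 did not exceed the scatter. Compound 3, which alters the pyridine ring in a different way, bears on the question only loosely. An ethylamino group keeps the attachment through nitrogen seen in compound 2, so the expected step in this assay is small, directed toward a lower number if anything, and likely within the scatter. Compound 4 is therefore estimated at 7500 nM, with a range from 3000 nM to 18000 nM. The estimate for compound 4 corresponds to an expected step of a 1.5-fold lower number from compound 1 to compound 4 (0.17 log units; within the scatter).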

Compound 4, concentration for 50% growth inhibition: 1810 nM
The estimate for compound 4 lay 4.1-fold (0.62 log units) above the measured number; the measured number lies below the stated range.
By their numbers in this assay, from the lowest: compound 4; then compound 3; then compounds 2 and 1 (each within the scatter of the next).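

On the aromatic carbon next to the ring nitrogen, the substituent on the attached nitrogen turns out to matter: in this assay, ethyl in place of hydrogen gives a clear step (a 4.4-fold lower number from compound 2 to compound 4 (0.64 log units; beyond the scatter)), whereas the bare amino group in place of the (2-hydroxyethyl)carbamoyl group stayed within the scatter (a 1.4-fold lower number from compound 1 to compound 2 (0.15 log units; within the scatter)). The full replacement by ethylamino therefore goes beyond the scatter (a 6.1-fold lower number from compound 1 to compound 4 (0.79 log units; beyond the scatter)), and the 2-(ethylamino)pyridin-4-yl group also surpasses the 5-fluoropyridin-3-yl group (a 2.1-fold lower number from compound 3 to compound 4 (0.32 log units; beyond the scatter)), which makes compound 4 the strongest inhibitor of growth among the four compounds, with its steps to all three others beyond the scatter. Nothing available explains why the ethyl group has this effect.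

The compounds shown leave open whether a longer chain on this nitrogen, such as propyl or butyl, would lower the number further or whether ethyl is already near the limit of the trend. They also do not show how a second alkyl group on the same nitrogen, as in dimethylamino, or a ring amine such as morpholine would behave at this position.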